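The source may report more compounds than this note shows. Statements on the series, on what has been measured and on what is new or still open speak of the compounds shown alone.

For the measured compounds named here, compound 1 `C[C@H](Nc1nc(N)nc(N)c1C#N)c1cc2ccc(F)cn2c(=O)c1-c1ccccc1` is one of two compounds measured in an ADME assay on microsomes from liver (Homo sapiens), read by LC-MS, using NADPH, with a stated time of 30 min, tested at 1 uM (a higher number here means that more of the compound is left, a lower number that less of the compound is left), where compound 1 gives 87%. The only comparison available is compound 2 `Cc1nc(N)nc(N[C@@H](C)c2cc3ccc(F)cn3c(=O)c2-c2ccccc2)c1C#N`, which in this assay gives 83%; the step of a number 4 percentage points lower from compound 1 to compound 2 (within the scatter) leaves the two numbers within the scatter of each other, so compound 1 is not separated from compound 2 on the numbers shown. Compound 3 `C[C@H](Nc1nc(N)nc(N)c1C#N)c1c(-c2ccccc2)c(=O)n2cc(F)ccc2c1-c1ccccc1` differs from compound 1 by phenyl in place of hydrogen on an aromatic carbon. Going by the values given here, no measured step involves a change of this kind: the single step known, methyl in place of amino, concerns a different part of the shared core and was within the scatter. Compound 3 is therefore expected to stay near compound 1 in this assay, with a step of a number 9 percentage points lower from compound 1 to compound 3 (within the scatter) estimated and a wide range allowed. The estimate for compound 3 is 78%, between 55% and 92%.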

Compound 3, percent of the compound remaining in the Homo sapiens assay: 98%
For compound 3 the middle estimate is 20 percentage points below the measured one; measured number above the stated range.
By their numbers in the Homo sapiens assay, from the lowest: compounds 2 and 1 (each within the scatter of the next); then compound 3.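

For the compounds shown here, in the Homo sapiens assay, replacing hydrogen with phenyl gives the first step beyond the scatter, a number 11 percentage points higher from compound 1 to compound 3 (beyond the scatter); the earlier change, methyl in place of amino, did not separate its two compounds. This shows that the number responds to a change on this aromatic carbon, two atoms from the ring nitrogen, and that a group of this size is tolerated here without any loss in the amount left. In a physicochemical assay for lipophilicity, at pH 7.4 (a higher number here means a more lipophilic compound, a lower number a more polar compound), compound 1 gives 1.26 and compound 3 gives 2.49; the same change makes the compound clearly more lipophilic, so here more of the compound is left despite higher lipophilicity: the measured distribution coefficient of compound 1, 1.26, and of compound 3, 2.49, a number 1.23 log units higher (beyond the scatter)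

The compounds shown leave open whether the rise in the amount left belongs to phenyl itself or would also appear with a methyl group or a carboxylic acid on this carbon. They also leave open whether phenyl here would give a similar step in compound 2, which carries methyl in place of amino.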